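A Bromine Added to Compound 2: What to Expect

A few compounds are considered here, and "the series" means these few. Any claim that something is new, unique, unknown or untested is made for them only; others in the source may bear on it.

Of the compounds shown here, three have been measured so far. In a functional assay on SK-BR-3 cells (Homo sapiens) for cytotoxicity, read by MTT assay, with a stated time of 72 h (on this read-out higher numbers stand for an effect only at larger amounts of compound and lower numbers for an effect already at smaller amounts), compound 2 `O=c1cc(Nc2ccccc2)cc(-c2ccccc2)o1` gives 0.13 uM, the lowest of the three numbers. Compound 3 `COc1ccccc1Nc1cc(-c2ccccc2)oc(=O)c1` gives 0.54 uM in this assay. Compound 1 `COc1ccc(Nc2cc(C3CCCCC3)oc(=O)c2)cc1` differs from compound 2 in two places, and in this assay compound 1 gives 5.29 uM, the value furthest from that of compound 2. The one single-point step among these, a 4.2-fold higher number from compound 2 to compound 3 (0.62 log units; beyond the scatter), shows a methoxy group entering an aromatic carbon and raising the number modestly.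

Compound 4 `O=c1cc(Nc2ccc(Br)cc2)cc(-c2ccccc2)o1` has not yet been measured. It differs from compound 2 by bromo in place of hydrogen on an aromatic carbon. Among the compounds with values here, no measured step puts a bromine on any ring, so the only guide is the methoxy step from compound 2 to compound 3, which weakened the effect modestly, together with the much wider gap between compound 2 and compound 1, which changes two things at once and so cannot be tied to a single cause. A small rise in number, or none beyond the scatter, is therefore expected in this assay for compound 4. The estimate is that compound 4 will give 0.3 uM, within 0.08 uM to 1.2 uM. This corresponds to an expected step of a 2.3-fold higher number from compound 2 to compound 4 (0.36 log units; beyond the scatter).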

Compound 4, concentration for half-maximal effect: 0.4 uM
The estimate for compound 4 lay 1.3-fold (0.12 log units) below the measured number, within the range that was stated.
By their numbers in this assay, from the lowest: compound 2; then compounds 4 and 3 (each within the scatter of the next); then compound 1.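

In this assay there is a 3.1-fold higher number from compound 2 to compound 4 (0.49 log units; beyond the scatter) when one bromine atom replaces a hydrogen para to a large group, so even this single added heavy atom, with no ring and no hydrogen-bond donors or acceptors of its own, moves the number beyond the scatter. Read beside a 4.2-fold higher number from compound 2 to compound 3 (0.62 log units; beyond the scatter) for the methoxy group, this gives two single changes on an aromatic ring of compound 2, and both lead to a higher number, so among these single steps the unsubstituted phenyl gives the lowest number and no step goes against that. Nothing shown gives a measured reason for this rise.

The compounds shown leave open whether any group at this place would raise the number or whether this is particular to bromo, and a fluorine, a methyl group, an amine or a carboxylic acid in the same spot would help to separate those two readings. They also leave open whether the bromine would give a step of similar size on the core of compound 1, where the phenyl of compound 2 is replaced by a different ring.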